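The source may report more compounds than this note shows. Statements on the series, on what has been measured and on what is new or still open speak of the compounds shown alone.

Compound 1 `COc1ccc(CN(C(=O)CCCl)c2cc(OC)c(OC)c(OC)c2)cc1O`: 110 nM
Compound 2 `COc1ccc(CNc2cc(OC)c(OC)c(OC)c2)cc1[N+](=O)[O-]`: 16800 nM
Compound 3 `C/C=C/C(=O)N(Cc1ccc(OC)c(OC)c1)c1cc(OC)c(OC)c(OC)c1`: 39100 nM

All three values come from a functional assay on KYSE-450 cells (Homo sapiens) for inhibition, read by MTT assay, with a stated time of 48 h; on this read-out higher numbers stand for weaker inhibition and lower numbers for stronger inhibition. Compound 1 gives the lowest number of the three; compound 2 and compound 3 both sit far above it, beyond the scatter, so compound 1 is the strongest inhibitor among the measured compounds. Compound 4 `COc1ccc(CN(C(=O)C(C)Br)c2cc(OC)c(OC)c(OC)c2)cc1O` has not been measured. It differs from compound 1 in a single place: 1-bromoethyl in place of 2-chloroethyl on a carbonyl carbon. Among the compounds with values here, no measured pair shows this change, so its effect is not known from the data. The step of a 2.7-fold higher number from compound 1 to compound 4 (0.44 log units; beyond the scatter) is expected to be modest, toward weaker inhibition, and may not pass beyond the scatter. Compound 4 is estimated at 300 nM, with a range from 80 nM to 2000 nM.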

Compound 4, half-maximal inhibitory concentration: 160 nM
Beside the measured number, compound 4's estimate is 1.9-fold (0.27 log units) above it; low and high end bracket the measured number.
By their numbers in this assay, from the lowest: compounds 1 and 4 (each within the scatter of the next); then compound 2; then compound 3.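

In this assay, 1-bromoethyl in place of 2-chloroethyl on a carbonyl carbon gives a 1.5-fold higher number from compound 1 to compound 4 (0.16 log units; within the scatter). Within the data shown here, this is the first reading of any swap at this position, and it shows that the two groups cannot be told apart here, even though the halogen and its place on the chain both differ. Nothing measured here bears on this result. The compounds shown leave open whether plain ethyl, a longer chain or an amine on the same carbonyl carbon would keep the number at this level.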